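The source may hold more compounds than are shown below. What is called first, only, known or untested is meant among the compounds shown, and "the series" means these compounds.

Measured so far in a functional assay on blood for antagonist activity at thromboxane A2 receptor (Homo sapiens); on this read-out higher numbers stand for weaker binding and lower numbers for tighter binding:
compound 1 `O=C(O)CC/C=C\CO[C@H]1[C@@H](OCc2ccc(-c3ccccc3)cc2)CC[C@@H]1N1CCCCC1`: 10 nM; 7.94 nM (2 entries)
compound 2 `O=C(O)CC/C=C\CO[C@H]1C(OCc2ccc(-c3ccccc3)cc2)CC[C@@H]1N1CCCCCC1`: 12.6 nM

Compound 1 has been run more than once (the several entries of compound 1 in this assay, 10 nM; 7.94 nM (2 entries)). Compound 2 rests on a single number; one further entry for it gives no single number.

Compound 3 `CC(=O)NCc1ccccc1-c1ccc(COC2CC[C@H](N3CCCCCC3)[C@H]2OC/C=C\CCC(=O)O)cc1` has not yet been measured in this assay. It differs from compound 2 by acetamidomethyl in place of hydrogen on an aromatic carbon. Among the measured compounds shown here, no comparable step is available among the measured compounds, so the effect of this addition is an open question; the expectation is a change no larger than the scatter, in either direction, with a 1.2-fold higher number from compound 2 to compound 3 (0.08 log units; within the scatter). Compound 3 is therefore estimated at 15 nM, between 4 nM and 60 nM.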

Compound 3, dissociation constant: 25.1 nM
Beside the measured number, compound 3's estimate is 1.7-fold (0.22 log units) below it, and the stated range covers the measured number.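

In this assay, the series now has its first step at this position, a 2.0-fold higher number from compound 2 to compound 3 (0.30 log units; within the scatter), with acetamidomethyl entering on an aromatic carbon, ortho to a large group. This position on the phenyl therefore accepts the whole acetamidomethyl group without a step beyond the scatter. Repeat readings give a sense of the spread against which this single step stands: the several entries of compound 1 in this assay, 10 nM; 7.94 nM (2 entries)

This remains one step on one core. Open, as far as these compounds go, is how an amine or a carboxylic acid at this place would read, and whether a longer chain would also stay within the scatter.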